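A methyl on the nitrogen of compound 1

The source may hold more compounds than are shown below. What is called first, only, known or untested is meant among the compounds shown, and "the series" means these compounds.

In a physicochemical assay for solubility, read by HPLC, at pH 7.4 (a lower number here means a less soluble compound, a higher number a more soluble compound), compound 1 `CCCCCCCc1cc(=O)c2cc(C(F)(F)F)ccc2[nH]1` gives < 5000 nM, which is a limit of the assay and not a number. In the same assay, this assay, compound 2 `CCCCCCCc1cc(=O)c2cc([N+](=O)[O-])ccc2[nH]1` gives < 5000 nM, again a limit. For the measured compounds named here, the one measured step, a step that the two limits leave unreadable from compound 1 to compound 2, therefore has no size to pass on, and the evidence so far amounts to the limit of < 5000 nM in this assay, at which 2 of the 2 values shown sit.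

Compound 3 `CCCCCCCc1cc(=O)c2cc(C(F)(F)F)ccc2n1C` differs from compound 1 by methyl in place of hydrogen on an aromatic nitrogen, ortho to a heptyl group. Going by the values given here, no measured step involves that nitrogen, so no direction can be argued, and no change beyond the scatter is expected in this assay. The expected step is a step that the limit leaves unreadable from compound 1 to compound 3. For compound 3 the estimated solubility is 3000 nM, with an expected range of 800 nM to 10000 nM.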

Compound 3, solubility: 5000 nM
For compound 3 the middle estimate is 1.7-fold (0.22 log units) below the measured one; measured number inside the range.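

In this assay compound 3 gives 5000 nM, an actual number. Compound 1 and compound 2 give only limits. Placing methyl on the aromatic nitrogen gives a number no lower from compound 1 to compound 3 (the limit leaves the size open), so this change does not lower the reading, but it may leave it unchanged or raise it by an unknown amount. As far as these compounds go, the size of the step stays unknown because the comparison starts from a limit: the limit of < 5000 nM in this assay, at which 2 of the 3 values shown sit.

From the compounds shown here alone, it remains open whether a larger group on this nitrogen, such as an ethyl group or a chain ending in an amine, would give a different reading. Also open, going by these compounds, are the effect of the same methyl on compound 2 and of a carboxylic acid at the end of the heptyl chain.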